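Working notes: bromo in place of chloro on compound 3

This account rests on a few compounds, and the source may have more. Where it says the series, first, only, none or still open, it means among the compounds named here.

Compound 1 `[O-][n+]1c(Cl)c(Br)cc2nc(O)c(O)nc21`: 18 mg/kg
Compound 2 `[O-][n+]1c(Cl)c(C(F)(F)F)cc2nc(O)c(O)nc21`: 30 mg/kg
Compound 3 `Cc1c(Cl)c[n+]([O-])c2nc(O)c(O)nc12`: 3 mg/kg

In a functional assay on the whole organism for antagonist activity, with Rattus norvegicus as the target (a lower number here means that less compound is needed, a higher number that more compound is needed for the effect), compound 3 has the lowest number of the three, and its value of 3 mg/kg compares with 18 mg/kg for compound 1 and 30 mg/kg for compound 2. Compound 4 `Cc1c(Br)c[n+]([O-])c2nc(O)c(O)nc12`, not yet measured, carries bromo in place of chloro on an aromatic carbon, ortho to a methyl group (bromo in place of chloro on an aromatic carbon).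

Among the measured compounds shown here, no measured pair makes this exchange directly. The nearest evidence is a single step with trifluoromethyl in place of bromo on an aromatic carbon, a 1.7-fold higher number from compound 1 to compound 2 (0.22 log units; within the scatter). That step involves bromo but not chloro, so it offers only weak guidance. With this one example, no step beyond the scatter is expected in this assay, and the expectation starts from the value of compound 3, 3 mg/kg. The estimated change is a 1.2-fold higher number from compound 3 to compound 4 (0.07 log units; within the scatter). For compound 4 the estimated value is 3.5 mg/kg, with an expected range of 1.5 mg/kg to 9 mg/kg.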

Compound 4, dose for half-maximal effect: 5 mg/kg
Beside the measured number, compound 4's estimate is 1.4-fold (0.15 log units) below it, and the stated range covers the measured number.
By their numbers in this assay, from the lowest: compounds 3 and 4 (each within the scatter of the next); then compounds 1 and 2 (each within the scatter of the next).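

In this assay bromo in place of chloro on this aromatic carbon, ortho to a methyl group, reads as a 1.7-fold higher number from compound 3 to compound 4 (0.22 log units; within the scatter) and gives the series its first direct pair for these two halogens. At this position the measurement does not separate bromo from chloro, something the earlier step between trifluoromethyl and bromo could not show. Nothing at hand bears on what lies behind this result.

Still open, going by these compounds, is how groups of another kind at this position, such as an amine, a methoxy group or a carboxylic acid, would read in this assay against these two halogens. One pair also leaves open whether bromo and chloro would still read alike with a longer chain, such as ethyl, in place of the methyl group.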